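The compounds below may be only part of what the source reports. "The series", "measured", "known", "first", "only" and "open" are said of these compounds alone.

Measured compounds:
compound 1 `CN1CCN(Cc2nnc(-c3cc(S(N)(=O)=O)c(SCc4ccccc4)cc3Cl)o2)CC1` — 75000 nM
compound 2 `NC(=O)c1cn(Cc2nnc(-c3cc(S(N)(=O)=O)c(SCc4ccccc4)cc3Cl)o2)nn1` — 78000 nM

The pair shares one core and differs only in the group carried on the saturated chain carbon bound to an aromatic carbon of that core. In a functional assay on MCF7 cells (Homo sapiens) for cytotoxicity, read by MTT assay, with a stated time of 72 h (a higher number here means a weaker inhibitor, a lower number a stronger inhibitor), compound 1 gives 75000 nM, and in this assay compound 2 gives 78000 nM. Within the data shown here, the single measured step, a 1.0-fold higher number from compound 1 to compound 2 (0.02 log units; within the scatter), swaps a basic, saturated ring for a carbamoyl-bearing triazole and moves the number hardly at all. Compound 2 therefore carries the higher of the two numbers, but its gap to compound 1 lies within the scatter, so no order between them can be claimed.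

Compound 3 `NS(=O)(=O)c1cc(-c2nnc(Cn3cc(-c4ccccc4)nn3)o2)c(Cl)cc1SCc1ccccc1` takes the next step from compound 2: phenyl in place of carbamoyl on an aromatic carbon. Among the measured compounds shown here, no measured step bears directly on replacing the carbamoyl with a phenyl, but the one step that is known, from compound 1 to compound 2, shows that a far larger change at this end of the molecule left the number where it was. The expected step in this assay is therefore none beyond the scatter, that is a 1.0-fold higher number from compound 2 to compound 3 (0.01 log units; within the scatter). For compound 3 the estimated value is 80000 nM, with a range of 30000 nM to 200000 nM.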

Compound 3, half-maximal inhibitory concentration: 170000 nM
Beside the measured number, compound 3's estimate is 2.1-fold (0.33 log units) below it, within the range that was stated.
By their numbers in this assay, from the lowest: compounds 1 and 2 (each within the scatter of the next); then compound 3.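

In this assay, the group on the triazole carbon proves able to move the number: phenyl in place of carbamoyl gives a 2.2-fold higher number from compound 2 to compound 3 (0.34 log units; beyond the scatter), a modest step that the earlier pair, level within the scatter, gave no sign of. The same separation appears against the saturated ring, where 4-phenyl-1H-1,2,3-triazol-1-yl in place of 4-methylpiperazin-1-yl gives a 2.3-fold higher number from compound 1 to compound 3 (0.36 log units; beyond the scatter), so among these three compounds only the phenyl-bearing one stands apart, and it does so in the direction of weaker inhibition. Nothing available explains this shift, and the data show only its size and direction.

The compounds shown leave open whether the step follows from the arrival of the phenyl ring or from the departure of the carbamoyl, a question that a small group such as methyl, an amine or a carboxylic acid on the same carbon would help to separate. They also leave open whether a phenyl ring bearing fluorine or a methoxy group, or a benzyl group in its place, would move the number further or bring it back.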